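The source may report more compounds than this note shows. Statements on the series, on what has been measured and on what is new or still open speak of the compounds shown alone.

Working notes on the series. The shared core is seen in compound 1 `O=C(NCc1ccc(CNS(=O)(=O)c2ccccc2)cc1)c1ccc([N+](=O)[O-])cc1`, which in an assay on MDA-MB-231 cells for binding affinity to C-X-C chemokine receptor type 4 (Homo sapiens), read by immunofluorescence and microscopy, with stated times of 10 min and 30 min (a lower number here means that less compound is needed, a higher number that more compound is needed for the effect), gives 100 nM. Compound 2 `Cc1ccc(S(=O)(=O)NCc2ccc(CNC(=O)c3ccc([N+](=O)[O-])cc3)cc2)cc1` gives 10 nM in this assay, and compound 3 `Cc1ccc(S(=O)(=O)NCc2ccc(CNC(=O)c3ccc(F)cc3)cc2)cc1` gives 1 nM. Compound 1 therefore stands highest of the three numbers; its nearest neighbour is compound 2 and compound 3 lies furthest from it. Two single changes have been measured: a 10-fold lower number from compound 1 to compound 2 (1.00 log units; beyond the scatter), methyl in place of hydrogen on an aromatic carbon, and a 10-fold lower number from compound 2 to compound 3 (1.00 log units; beyond the scatter), fluoro in place of nitro on an aromatic carbon.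

Compound 4 `COc1ccc(C(=O)NCc2ccc(CNS(=O)(=O)c3ccccc3)cc2)cc1` is not yet measured. Against compound 1 it differs in one place: methoxy in place of nitro on an aromatic carbon. Going by the values given here, of the measured steps only that from compound 2 to compound 3 bears on it: there too nitro leaves an aromatic carbon, with fluoro rather than methoxy entering, and that step was beyond the scatter. The methyl step from compound 1 to compound 2 sits on the other ring and says nothing about this change. Methoxy is a different group from fluoro, so the size carried over is uncertain, but the direction expected in this assay is toward a lower number. For compound 4 the expected step is a 3.3-fold lower number from compound 1 to compound 4 (0.52 log units; beyond the scatter). Compound 4 is thus estimated at 30 nM, with a range from 5 nM to 200 nM.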

Compound 4, effective concentration (reported as EC, without a stated level of effect): 1000 nM
Compound 4: middle estimate off by 33-fold (1.52 log units), on the low side, and the stated range ends below it.
By their numbers in this assay, from the lowest: compound 3; then compound 2; then compound 1; then compound 4.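

The nitro position, para to a large group, does not move in one direction when nitro leaves: with methoxy entering, this assay shows a 10-fold higher number from compound 1 to compound 4 (1.00 log units; beyond the scatter) with the core of compound 1, while with fluoro entering it shows a 10-fold lower number from compound 2 to compound 3 (1.00 log units; beyond the scatter) with the methyl-bearing core. Loss of nitro alone therefore does not set the direction in this pair of steps, and the entering group, the methyl on the other ring, or the two together must count, since the two steps differ in both. No measurement at hand accounts for the difference between methoxy and fluoro at this position.

The compounds shown leave open whether methoxy would give a step of the same direction on the methyl-bearing core, and whether fluoro would do so on the core of compound 1, which would separate the entering group from its background. Also open, from the compounds shown here alone, is how an amine, a nitrile or a carboxylic acid at this same position would read, and so whether fluoro or methoxy is the exception among replacements for nitro.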